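This account rests on a few compounds, and the source may have more. Where it says the series, first, only, none or still open, it means among the compounds named here.

- compound 1 `CCCC(=O)n1c(=S)[nH]c2ccccc21`: 190000 nM
- compound 2 `CCCCCC(=O)n1c(=S)[nH]c2ccccc21`: 170000 nM
- compound 3 `CCn1c(=S)n(C(C)=O)c2ccccc21`: 380000 nM
- compound 4 `CC(=O)n1c(=S)[nH]c2ccccc21`: not yet measured

In a physicochemical assay for solubility (a higher number here means a more soluble compound, a lower number a less soluble compound), compound 3 has the highest number of the three. Only its gap to compound 2 lies beyond the scatter, while its gap to compound 1 lies within it.

Compound 4 differs from compound 3 in one place: hydrogen in place of ethyl on an aromatic nitrogen. In words, hydrogen stands in place of ethyl on an aromatic nitrogen. For the measured compounds named here, no measured step covers this exact change. Going by the values given here, the only measured step is a 1.1-fold lower number from compound 1 to compound 2 (0.05 log units; within the scatter), which lies within the scatter and concerns the chain on the carbonyl, not the nitrogen. Still, compound 1 and compound 2 carry the same hydrogen as compound 4 and differ from it only in that chain. Their values, compound 1 at 190000 nM and compound 2 at 170000 nM, are therefore the best guide. The expected step is a 1.5-fold lower number from compound 3 to compound 4 (0.18 log units; within the scatter), a move towards a lower number that would stay within the scatter. For compound 4 the estimated value is 250000 nM, with an expected range from 130000 nM to 480000 nM.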

Compound 4, solubility: 460000 nM
Beside the measured number, compound 4's estimate is 1.8-fold (0.26 log units) below it; the range from low to high includes it.
By their numbers in this assay, from the lowest: compounds 2, 1, 3 and 4 (each within the scatter of the next, the first and the last beyond it).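

In this assay, for the compounds shown here, hydrogen in place of ethyl on the aromatic nitrogen makes no clear difference, with a 1.2-fold higher number from compound 3 to compound 4 (0.08 log units; within the scatter), so this nitrogen tolerates either group in the one pair that tests it. The chain on the carbonyl now shows a real effect, which the earlier step between butanoyl-type and longer chains, within the scatter, could not: hydrogen in place of butyl gives a 2.7-fold higher number from compound 2 to compound 4 (0.43 log units; beyond the scatter), and hydrogen in place of ethyl gives a 2.4-fold higher number from compound 1 to compound 4 (0.38 log units; beyond the scatter), both on the saturated chain carbon bound to a carbonyl carbon. No measurement here offers an explanation for these numbers.

From the compounds shown here alone, what remains open is how a longer chain or an amine on the aromatic nitrogen would read in this assay. A carboxylic acid on the chain at the carbonyl is equally untested among the compounds shown.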